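Cytotoxicity notes on a chlorinated indole sulfone amide series

The source may hold more compounds than are shown below. What is called first, only, known or untested is meant among the compounds shown, and "the series" means these compounds.

Measured so far:
- compound 1 `Cc1cc(C)cc(S(=O)(=O)c2c(C(=O)NC(C)C(=O)NCCn3c(C)cnc3[N+](=O)[O-])[nH]c3ccc(Cl)cc23)c1`: in an ADME assay on MT4 cells (Homo sapiens) for cytotoxicity, read by MTT assay (a higher number here means that more compound is tolerated, a lower number that less compound is tolerated), compound 1 gives 16000 nM
- compound 2 `Cc1cc(C)cc(S(=O)(=O)c2c(C(=O)NCC(=O)NCCn3c(C)cnc3[N+](=O)[O-])[nH]c3ccc(Cl)cc23)c1`: in this assay compound 2 gives 24500 nM

Among the measured compounds shown here, compound 1 stands lowest of the two numbers, with compound 2 nearest; the only measured step, a 1.5-fold higher number from compound 1 to compound 2 (0.19 log units; within the scatter), is within the scatter.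

Compound 3 `Cc1cc(C)cc(S(=O)(=O)c2c(C(=O)NC(C)C(=O)NC(C)c3ccncc3)[nH]c3ccc(Cl)cc23)c1` is not yet measured. It differs from compound 1 by a group of 8 heavy atoms (7 carbon, 1 nitrogen; one six-membered aromatic ring with 1 hetero atom) in place of a group of 11 heavy atoms (6 carbon, 3 nitrogen, 2 oxygen; one five-membered aromatic ring with 2 hetero atoms), on an amide-type nitrogen. For the measured compounds named here, the one measured step concerns a different place, a hydrogen in place of methyl on a saturated chain carbon, and gives no guide to what the exchange at the amide-type nitrogen does; the two values to hand merely show both compounds tolerated at a similar level. With nothing bearing on this change, no step beyond the scatter is expected in this assay, though the range must stay wide. Compound 3 is therefore estimated at 16000 nM, between 5000 nM and 50000 nM, an expected step of no change at the digits printed from compound 1 to compound 3 (within the scatter).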

Compound 3, half-maximal cytotoxic concentration: 21900 nM
For compound 3 the middle estimate is 1.4-fold (0.14 log units) below the measured one; the range from low to high includes it.
By their numbers in this assay, from the lowest: compounds 1, 3 and 2 (each within the scatter of the next).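

At the amide-type nitrogen, 1-(pyridin-4-yl)ethyl takes the place of the group with the five-membered aromatic ring, and this assay shows a 1.4-fold higher number from compound 1 to compound 3 (0.14 log units; within the scatter). Among the compounds shown here, this is the first view of this position, and the exchange alters ring size, heavy-atom count and hydrogen-bond acceptor count at once without a step beyond the scatter. In this assay, the group that leaves is therefore not needed to keep the tolerated level of compound 1, and nothing available bears on why the two groups read alike.

Still open, going by these compounds, is whether the position stays as undemanding with a group of another kind on the amide-type nitrogen, such as a dimethylaminoethyl chain or a carboxymethyl group. Also open, on these data alone, is how 1-(pyridin-4-yl)ethyl reads with hydrogen in place of methyl on the saturated chain carbon.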